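Growth inhibition notes: from compound 3 to compound 4

This account rests on a few compounds, and the source may have more. Where it says the series, first, only, none or still open, it means among the compounds named here.

In a functional assay on DU-145 cells (Homo sapiens) for inhibition, read by trypan blue exclusion, with a stated time of 96 h (a lower number here means a stronger inhibitor of growth, a higher number a weaker inhibitor of growth), compound 1 `COc1ccccc1/C=C(\C(=O)c1ccc(Br)cc1)S(=O)(=O)c1ccc(C)cc1` gives 1000 nM. Compound 3 `COc1ccc(/C=C(\C(=O)c2ccc(Br)cc2)S(=O)(=O)c2ccc(C)cc2)cc1` gives 1000 nM, level with compound 1. Compound 2 `Cc1ccc(S(=O)(=O)/C(=C/c2c(O)cc(O)cc2O)C(=O)c2ccc(Br)cc2)cc1` reaches only a limit of the assay, > 100000 nM.

Next in the series is compound 4 `Cc1ccc(S(=O)(=O)/C(=C/c2c[nH]c3ccc(Cl)cc23)C(=O)c2ccc(Br)cc2)cc1`, which differs from compound 3 as follows: 5-chloro-1H-indol-3-yl in place of 4-methoxyphenyl on a double-bonded chain carbon bound to a double-bonded chain carbon. The change is 5-chloro-1H-indol-3-yl in place of 4-methoxyphenyl on a double-bonded chain carbon bound to a double-bonded chain carbon.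

Going by the values given here, the measured steps at this same place are the only guide. Placing 4-methoxyphenyl where 2-methoxyphenyl stood gave no change at the digits printed from compound 1 to compound 3 (within the scatter). Placing 2,4,6-trihydroxyphenyl there gave an at least 100-fold higher number from compound 1 to compound 2 (2.00 log units; beyond the scatter), and the swap from that group to 4-methoxyphenyl gave an at least 100-fold lower number from compound 2 to compound 3 (2.00 log units; beyond the scatter). Both large steps rest on the limit of compound 2, so their true size is open. Among the compounds with values here, no measured compound carries the entering group, and the steps therefore show that this place can matter without giving a direction for compound 4.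

Within the data shown here, with the step of no change at the digits printed from compound 1 to compound 3 (within the scatter) as the nearest precedent, the expected outcome in this assay is no change at the digits printed from compound 3 to compound 4 (within the scatter). For compound 4 the estimated value is 1000 nM, with an expected range from 200 nM to 5000 nM.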

Compound 4, concentration for 50% growth inhibition: 10000 nM
Beside the measured number, compound 4's estimate is 10-fold (1.00 log units) below it; the measured number lies above the stated range.
By their numbers in this assay, from the lowest: compounds 1 and 3 (each within the scatter of the next); then compound 4. At a limit, above all of these: compound 2.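

Compound 4 gives this place its first finite loss in this assay: a 10-fold higher number from compound 3 to compound 4 (1.00 log units; beyond the scatter), and likewise a 10-fold higher number from compound 1 to compound 4 (1.00 log units; beyond the scatter). The earlier compounds showed only the equal results of the 2-methoxyphenyl and 4-methoxyphenyl groups and a single compound at a limit, whereas this result adds a level between those extremes, so the outcome at this place is not simply all or nothing among the groups shown. On the other side of compound 4 stands an at least 10-fold lower number from compound 2 to compound 4 (1.00 log units; beyond the scatter), and that step is only a bound, since the value of compound 2 is a limit and not a number: the limit of > 100000 nM in this assay, at which 1 of the 4 values shown sits.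

The entering group differs from 4-methoxyphenyl in several ways at once, so the compounds shown do not tell whether the chlorine or the 1H-indol-3-yl ring system carries the step. Still open, as far as these compounds go, are a plain 1H-indol-3-yl group without chlorine, a 5-methoxy-1H-indol-3-yl group, and a phenyl ring bearing a single hydroxyl or an amine at this place, any of which would help to separate those contributions.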